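Two Anilines at the Limit, One Chloromethylphenyl Unmeasured

The source may hold more compounds than are shown below. What is called first, only, known or untested is meant among the compounds shown, and "the series" means these compounds.

In an ADME assay on L02 cells (Homo sapiens) for antiproliferative activity, read by MTT assay, with a stated time of 48 h (a higher number here means a weaker inhibitor, a lower number a stronger inhibitor), compound 1 `N#CC1=C(N)Oc2c(c3nc4ccccc4nc3c3ccccc23)C12C(=O)N(Cc1cnnn1-c1ccccc1Cl)c1ccccc12` gives > 50000 nM, which is a limit of the assay rather than a number. Compound 2 `N#CC1=C(N)Oc2c(c3nc4ccccc4nc3c3ccccc23)C12C(=O)N(Cc1cnnn1-c1cccc(S(N)(=O)=O)c1)c1ccccc12` likewise gives > 50000 nM in this assay, again a limit. Within the data shown here, the one step between them, a step that the two limits leave unreadable from compound 1 to compound 2, therefore cannot be read, and the only evidence available is the limit of > 50000 nM in this assay, at which 2 of the 2 values shown sit. Compound 3 `Cc1ccc(-n2nncc2CN2C(=O)C3(C(C#N)=C(N)Oc4c3c3nc5ccccc5nc3c3ccccc43)c3ccccc32)cc1Cl` is not yet measured; it differs from compound 2 by 3-chloro-4-methylphenyl in place of 3-sulfamoylphenyl on an aromatic nitrogen. Among the measured compounds shown here, no measured step is informative here, since both values that bear on it are limits, so nothing beyond the scatter can be expected in either direction, and the most likely outcome is that compound 3 also sits at the limit. Compound 3 is therefore expected to give about 60000 nM in this assay, within 20000 nM to 200000 nM, which would mean a step that the limit leaves unreadable from compound 2 to compound 3 that is an estimate only.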

Compound 3, half-maximal inhibitory concentration: > 50000 nM
Compound 3 ended at the assay's limit; the forecaster's own chance of this, stated with the estimate: 80%; the middle value does not contradict the limit.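

In this assay compound 3 gives > 50000 nM as a limit of the assay and not a number. Among these compounds, no step among compound 1, compound 2 and compound 3 can be read. The compounds shown leave open whether in this assay any group on that aromatic nitrogen gives a readable value.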